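The source may report more compounds than this note shows. Statements on the series, on what has been measured and on what is new or still open speak of the compounds shown alone.

In an ADME assay on microsomes from liver (Homo sapiens) for metabolic stability, read by LC-MS, using NADPH, with a stated time of 30 min, tested at 1 uM (a lower number here means that less of the compound is left, a higher number that more of the compound is left), the three measured compounds stand as follows:

compound 1, `COC(=O)C1=C(Nc2ccccc2F)O/C(=C\c2c[nH]c3ncccc23)C1=O`, with 30%
compound 2, `COC(=O)C1=C(Nc2ccc(C)cc2C)O/C(=C\c2c[nH]c3ncccc23)C1=O`, with 63%
compound 3, `COC(=O)C1=C(Nc2ccccc2Cl)O/C(=C\c2c[nH]c3ncccc23)C1=O`, with 67%

Compound 3 gives the highest of the three numbers, though its gap to compound 2 lies within the scatter, while compound 1 sits far below both: a number 37 percentage points higher from compound 1 to compound 3 (beyond the scatter) and a number 33 percentage points higher from compound 1 to compound 2 (beyond the scatter). Compound 4, `COC(=O)C1=C(Nc2ccc(F)cc2)O/C(=C\c2c[nH]c3ncccc23)C1=O`, differs from compound 3 in one place: 4-fluorophenyl in place of 2-chlorophenyl on an amine nitrogen. Within the data shown here, only one measured step touches the same exchange of halogens, a number 37 percentage points higher from compound 1 to compound 3 (beyond the scatter), and it runs the other way, chloro in place of fluoro. The fluorine in compound 4 is not placed as in compound 1, so the comparison is loose, but it is the only one available. A drop toward the value of compound 1 is therefore expected, of moderate size, a number 27 percentage points lower from compound 3 to compound 4 (beyond the scatter), and compound 4 is estimated at 40%, between 20% and 65%.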

Compound 4, percent of the compound remaining: 52%
Estimate against measurement, compound 4: 12 percentage points below, and the stated range covers the measured number.
By their numbers in this assay, from the lowest: compound 1; then compound 4; then compounds 2 and 3 (each within the scatter of the next).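

In this assay, the 2-fluorophenyl and 4-fluorophenyl groups on the amine nitrogen do not give the same result, a number 22 percentage points higher from compound 1 to compound 4 (beyond the scatter), so the earlier low number does not follow from fluoro alone and depends on which of these two groups is present. The 4-fluorophenyl group nevertheless falls short of both other groups, a number 15 percentage points lower from compound 3 to compound 4 (beyond the scatter) and a number 11 percentage points lower from compound 2 to compound 4 (beyond the scatter), which places compound 4 apart from compounds 2 and 3 as well as from compound 1. No measurement shown here bears on the cause of these differences.

The compounds shown leave open how a nitrile, a methoxy group or a carboxylic acid on the phenyl ring would stand. They also leave open whether a longer alkyl chain on the amine nitrogen would match compounds 2 and 3.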